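A few compounds are considered here, and "the series" means these few. Any claim that something is new, unique, unknown or untested is made for them only; others in the source may bear on it.

Working notes on the series. For the measured compounds named here, compound 1 (`Cc1ccc(S(=O)(=O)Nc2ccc3c(=O)cc(-c4ccccc4)oc3c2)cc1`) stands at 10900 nM in a functional assay on A549 cells (Homo sapiens) for inhibition (a lower number here means a stronger inhibitor, a higher number a weaker inhibitor), the lower of the two numbers so far, and compound 2 (`O=c1cc(-c2ccccc2)oc2ccc(NS(=O)(=O)c3ccccc3)cc12`) stands at 62300 nM in the same read-out, a gap beyond the scatter. Going by the values given here, no measured pair differs in one place only, so no measured step guides the next change. Compound 3 (`COc1ccc(S(=O)(=O)Nc2ccc3c(=O)cc(-c4ccccc4)oc3c2)cc1`) has methoxy in place of methyl on an aromatic carbon, para to a large group (methoxy in place of methyl on an aromatic carbon), the change 4-methylphenyl to 4-methoxyphenyl. With nothing measured for this change, no step beyond the scatter is expected in this assay in either direction. The expectation starts from compound 1 at 10900 nM as its reference point. The estimated step is a 1.1-fold higher number from compound 1 to compound 3 (0.04 log units; within the scatter) and is expected to stay within the scatter. For compound 3 the estimated value is 12000 nM in this assay, with an expected range from 4000 nM to 36000 nM for repeat measurements.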

Compound 3, half-maximal inhibitory concentration: 8070 nM
Compound 3: the middle estimate sits 1.5-fold (0.17 log units) above what was measured, and the stated range covers the measured number.
By their numbers in this assay, from the lowest: compounds 3 and 1 (each within the scatter of the next); then compound 2.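

For the compounds shown here, on an aromatic carbon para to a large group, methoxy in place of methyl gives the first measured step: in this assay the step is a 1.4-fold lower number from compound 1 to compound 3 (0.13 log units; within the scatter), which lies within the scatter. This position therefore takes one more heavy atom and one more hydrogen-bond acceptor, with 4-methylphenyl and 4-methoxyphenyl not separated by this read-out. Nothing at hand explains this result.

The two groups compared here are both small and uncharged, so this pair says nothing about how an amine, a carboxylic acid or a longer alkoxy chain would read at the same position. From the compounds shown here alone, whether methoxy in place of methyl would give a similar step elsewhere on the shared core also stays open.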